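Swapping one ring for another on a shared core

This account rests on a few compounds, and the source may have more. Where it says the series, first, only, none or still open, it means among the compounds named here.

Of the compounds shown here, three built on one core have been measured in a physicochemical assay for acid dissociation. Compound 1 `Fc1ccc(Cc2ccc3c(NCCCNCc4ccco4)ccnc3c2)c(Cl)c1` gives 9.47. Compound 2 `c1coc(CNCCCNc2ccnc3cc(-c4cccc5ccccc45)ccc23)c1` gives 9.47. Compound 3 `COc1cccc(CNCCCNc2ccnc3cc(Cc4ccc(F)cc4Cl)ccc23)c1O` gives 9.47.

Compound 2 differs from compound 1 in one place: naphthalen-1-yl in place of 2-chloro-4-fluorobenzyl on an aromatic carbon. That swap made the step of no change at the digits printed from compound 1 to compound 2 (within the scatter). Compound 3 differs from compound 1 in another place: 2-hydroxy-3-methoxyphenyl in place of furan-2-yl on a saturated chain carbon bound to an amine nitrogen. That swap made the step of no change at the digits printed from compound 1 to compound 3 (within the scatter). Compounds 1 and 2 have no counted difference from compound 3 beyond this, so the core that compound 3 and compound 4 share differs from the core of compounds 1 and 2 only by this change.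

Compound 4 `COc1cccc(CNCCCNc2ccnc3cc(-c4cccc5ccccc45)ccc23)c1O` has not yet been measured in this assay. It differs from compound 3 as follows: naphthalen-1-yl in place of 2-chloro-4-fluorobenzyl on an aromatic carbon. This is the same change that led from compound 1 to compound 2, made at a place described in the same words, so the two changes are the same. Because the earlier step of no change at the digits printed from compound 1 to compound 2 (within the scatter) stayed within the scatter, the step from compound 3 to compound 4 is expected to be no change at the digits printed from compound 3 to compound 4 (within the scatter). With the three measured values all standing at one level, compound 4 is estimated at 9.47, with an expected range from 9.2 to 9.75.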

Compound 4, acid dissociation constant: 9.47
Beside the measured number, compound 4's estimate shows no gap at the digits printed; the range from low to high includes it.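

In this assay the swap of 2-chloro-4-fluorobenzyl for naphthalen-1-yl gave no change at the digits printed from compound 1 to compound 2 (within the scatter) and, on the second core, no change at the digits printed from compound 3 to compound 4 (within the scatter) so on these two cores the change behaves alike, and the swap of furan-2-yl for 2-hydroxy-3-methoxyphenyl, read on the naphthalen-1-yl compounds, likewise gave no change at the digits printed from compound 2 to compound 4 (within the scatter) which closes a square of four compounds with no readable step on any side. Within the data shown here, this shows only that a change with no readable effect on one core also had none on one other core; with no step of real size anywhere in the square, it does not test whether a real shift would carry over from core to core, and it says nothing about any third core. Nothing shown here offers a measured reason why the value holds level across these compounds.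

The compounds shown leave open whether the read-out would stay level with an amine or a carboxylic acid in place of naphthalen-1-yl on that aromatic carbon. They also leave open whether a longer chain between the two nitrogens of the shared core would leave it level.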